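This account rests on a few compounds, and the source may have more. Where it says the series, first, only, none or still open, it means among the compounds named here.

The study compares four compounds built on two closely related cores. Compound 1 `Nc1cccc(-c2cn3nc(Cc4ccccc4)sc3n2)c1` and compound 2 `Nc1cccc(-c2cn3nc(Cc4ccc(Cl)cc4)sc3n2)c1` share one core, while compound 3 `Nc1cccc(-c2cn3c(-c4ccc(Cl)cc4)csc3n2)c1` and compound 4 `Nc1cccc(-c2cn3c(-c4ccccc4)csc3n2)c1` share the other. The difference between the two cores is not broken down here.

In a functional assay on FM3A cells (Mus musculus) for inhibition, read by cell counting, with a stated time of 2 days (a higher number here means a weaker inhibitor, a lower number a stronger inhibitor), compound 1 gives 4700 nM, compound 2 gives 6000 nM, and compound 3 gives 11000 nM. Among the three measured numbers that of compound 3 is the highest, though its distance to compound 2 stays within the scatter and only its distance to compound 1 goes beyond it. On the first core the structural change hydrogen in place of chloro on an aromatic carbon produced a 1.3-fold lower number from compound 2 to compound 1 (0.11 log units; within the scatter). The same change, applied to the second core, turns compound 3 into compound 4: hydrogen in place of chloro on an aromatic carbon. The surroundings of the place are described in identical terms for both pairs. This is treated as the same change. The step is expected to resemble the earlier one, a 1.3-fold lower number from compound 3 to compound 4 (0.11 log units; within the scatter), because the comparable step was a 1.3-fold lower number from compound 2 to compound 1 (0.11 log units; within the scatter). Compound 4 is therefore estimated at 8500 nM, with a likely range from 4000 nM to 18000 nM.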

Compound 4, half-maximal inhibitory concentration: 34000 nM
Beside the measured number, compound 4's estimate is 4.0-fold (0.60 log units) below it, and the stated range ends below it.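

In this assay the change from 4-chlorophenyl to phenyl gives a 3.1-fold higher number from compound 3 to compound 4 (0.49 log units; beyond the scatter), and this step does not match its counterpart on the other core: the same change on two cores in this assay, a 1.3-fold lower number (0.11 log units; within the scatter) from compound 2 to compound 1 and a 3.1-fold higher number (0.49 log units; beyond the scatter) from compound 3 to compound 4, 3.9-fold (0.60 log units) apart, beyond the scatter of two such steps. In this series, then, the size of the step did not carry over from the core of compound 2 to the core of compound 3, so a step read on one of these cores is a poor guide to the same change on the other. Among the compounds shown here, this does not show why the two steps part, and with only one pair on each core it does not establish a general rule for either core.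

As far as these compounds go, it remains open whether the gap between the cores is particular to chloro or would also appear with another group on the same aromatic carbon, such as fluoro, methoxy or an amine. From the compounds shown here alone, it also remains open whether the step on the core of compound 3 would keep its size with any such group.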